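The source may report more compounds than this note shows. Statements on the series, on what has been measured and on what is new or still open speak of the compounds shown alone.

Of the compounds shown here, three on the shared core have been read so far: compound 1 (`N#Cc1ccc(-c2nc(NCCNc3ccc([N+](=O)[O-])c(N)n3)ncc2-c2ncc[nH]2)cc1`), compound 2 (`Nc1nc(NCCNc2ncc(-c3ncc[nH]3)c(-c3ccc(Cl)cc3)n2)ccc1[N+](=O)[O-]`) and compound 3 (`Nc1nc(NCCNc2ncc(-c3ncc[nH]3)c(-c3ccccc3Cl)n2)ccc1[N+](=O)[O-]`). In an ADME assay on microsomes from liver (Rattus norvegicus) for metabolic stability (on this read-out lower numbers stand for a shorter-lived compound and higher numbers for a longer-lived compound), compound 1 gives > 0.5 h as a limit and not a number. Compound 2 gives > 0.5 h as a limit too. Compound 3 gives > 0.5 h as a limit as well, so it stands only where the whole set stands (the limit of > 0.5 h in this assay, at which 3 of the 3 values shown sit).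

Compound 4 (`Nc1nc(NCCNc2ncc(-c3ncc[nH]3)c(-c3ccccc3Br)n2)ccc1[N+](=O)[O-]`) has bromo in place of chloro on an aromatic carbon, ortho to a large group (bromo in place of chloro on an aromatic carbon). Among the measured compounds shown here, three measured steps bear on this, none of them the same exchange: (a step that the two limits leave unreadable from compound 2 to compound 3), (a step that the two limits leave unreadable from compound 1 to compound 2) and (a step that the two limits leave unreadable from compound 1 to compound 3). Each is left unreadable by its two limits, so together they give neither a size nor a direction. No step beyond the scatter is therefore expected in this assay for this change, and another limit is a likely outcome. The working estimate is an expected step (a step that the limit leaves unreadable from compound 3 to compound 4) and no more. For compound 4 the estimated half-life is 0.7 h with an expected range from 0.4 h to 2 h for now.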

Compound 4, half-life: > 0.5 h
Compound 4 ended at the assay's limit; the forecaster's own chance of this, stated with the estimate: 80%; the middle value is on the limit's open side.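

In this assay compound 4 gives > 0.5 h, a limit and not a number. No new step can be read from compound 1, compound 2 or compound 3 to compound 4. The compounds shown leave open the actual half-life of each one, and whether any exchange on the shared core changes it, with every value at one limit: the limit of > 0.5 h in this assay, at which 4 of the 4 values shown sit.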